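The compounds below may be only part of what the source reports. "The series", "measured", "known", "first", "only" and "open" are said of these compounds alone.

Measured so far:
compound 1 `Cc1ccccc1Nc1ncnc2c1ncn2C1O[C@H](CO)[C@@H](O)[C@H]1O`, 8.91 nM;
compound 2 `OC[C@H]1OC(n2cnc3c(Nc4ccc(Cl)cc4)ncnc32)[C@H](O)[C@@H]1O`, 2.19 nM;
compound 3 `COc1cccc(Nc2ncnc3c2ncn3C2O[C@H](CO)[C@@H](O)[C@H]2O)c1`, 46.8 nM.

All three share one core and differ only in the aryl group carried on the nitrogen attached to that core. In an assay on isolated protein for binding affinity to adenosine receptor A1 (Rattus norvegicus) (on this read-out higher numbers stand for weaker inhibition and lower numbers for stronger inhibition), compound 1 stands second highest of the three numbers: the step of a 4.1-fold lower number from compound 1 to compound 2 (0.61 log units; beyond the scatter) shows a modest move down, the step of a 5.3-fold higher number from compound 1 to compound 3 (0.72 log units; beyond the scatter) a modest move up, and the step of a 21-fold higher number from compound 2 to compound 3 (1.33 log units; beyond the scatter) spans the whole spread.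

Compound 4 `COc1ccccc1Nc1ncnc2c1ncn2C1O[C@H](CO)[C@@H](O)[C@H]1O` has not yet been measured. It differs from compound 1 by methoxy in place of methyl on an aromatic carbon. Going by the values given here, no measured step swaps methyl for methoxy at the same place, so the nearest guide is the step of a 5.3-fold higher number from compound 1 to compound 3 (0.72 log units; beyond the scatter), which also introduces a methoxy but moves it to a different position of the phenyl ring at the same time. That step mixes two changes, so only part of it is expected to carry over. The step to compound 4 in this assay is therefore estimated as a small rise in the number, a 1.8-fold higher number from compound 1 to compound 4 (0.25 log units; within the scatter), possibly within the scatter. Compound 4 is expected to give about 16 nM, with a range from 5 nM to 50 nM.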

Compound 4, half-maximal inhibitory concentration: 85.1 nM
Compound 4: middle estimate off by 5.3-fold (0.73 log units), on the low side; the measured number lies above the stated range.
By their numbers in this assay, from the lowest: compound 2; then compound 1; then compounds 3 and 4 (each within the scatter of the next).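

In this assay, the swap of methyl for methoxy on this aromatic carbon, ortho to a large group, is no minor edit: one extra heavy atom gives a 9.6-fold higher number from compound 1 to compound 4 (0.98 log units; beyond the scatter). The position of the methoxy on the phenyl ring makes no readable difference between these two compounds, since a 1.8-fold higher number from compound 3 to compound 4 (0.26 log units; within the scatter) is a gap that cannot be told from repeat-measurement noise, so the earlier rise seen with compound 3 need not be read as tied to its particular position. The 4-chlorophenyl group of compound 2 remains well apart from this methoxy compound, with a 39-fold higher number from compound 2 to compound 4 (1.59 log units; beyond the scatter), which stretches the spread of the series further than compound 3 had shown.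

The compounds shown offer no measurement that explains why methoxy raises the number so much at this place. On these data alone, it also stays open how a hydroxy group, an amine or a longer chain such as ethoxy would read at the same ring carbon, and so whether the rise belongs to methoxy alone or to any group containing oxygen there.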